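Ester to Ketone: Predicting Lipophilicity of Compound 4

This account rests on a few compounds, and the source may have more. Where it says the series, first, only, none or still open, it means among the compounds named here.

Measured compounds:
compound 1 `COC(C)(C)CCCC(C)C/C=C/C(C)=C/C(=O)OCCC(C)C`: 7.03
compound 2 `CCNC(=O)OC(C)(C)CCCC(C)C/C=C/C(C)=C/C(=O)OCC`: 5.65
compound 3 `CCSC(=O)/C=C(C)/C=C/CC(C)CCCC(C)C`: 7.98

Three compounds have been run in a physicochemical assay for lipophilicity; a lower number here means a more polar compound, a higher number a more lipophilic compound. Compound 1 stands second highest of the three: compound 3 lies higher by a margin beyond the scatter, and compound 2 lies lower by a larger margin, also beyond the scatter.

Compound 4 `CCCC(=O)/C=C(C)/C=C/CC(C)CCCC(C)(C)OC` is not yet measured. It differs from compound 1 in one place (propyl in place of isopentyloxy on a carbonyl carbon). Among the compounds with values here, no step between measured compounds matches this change, so its size can only be guessed. Since compound 1 gives 7.03, and the change removes heavy atoms, a downward step beyond the scatter is expected from compound 1 to compound 4, a number 1.43 log units lower from compound 1 to compound 4 (beyond the scatter). Compound 4 is therefore estimated at 5.6, within a range from 5 to 6.3.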

Compound 4, partition coefficient: 5.61
Estimate against measurement, compound 4: 0.01 log units below; low and high end bracket the measured number.
By their numbers in this assay, from the lowest: compounds 4 and 2 (each within the scatter of the next); then compound 1; then compound 3.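

Within the data shown here, with propyl in place of isopentyloxy on a carbonyl carbon, this assay moves by a number 1.42 log units lower from compound 1 to compound 4 (beyond the scatter) and gives the first step in this set that isolates a single change. It shows that this position of compound 1 is sensitive, as the step is large and lies beyond the scatter. Nothing measured here gives a cause for the step.

The compounds shown leave open how much of the step follows the lost chain oxygen and how much the shorter chain. An isopentyl group on the same carbonyl carbon would separate the two, and an amine there remains an open case.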